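Methoxy to hydrogen: from compound 3 to compound 4

The source may hold more compounds than are shown below. What is called first, only, known or untested is meant among the compounds shown, and "the series" means these compounds.

For the measured compounds named here, compound 3 `COc1ccc(-c2ccnc(C(=O)Nc3ccc(Oc4ccnc5[nH]ccc45)cc3)c2)cc1` is the only member of the set with a numerical read-out: in a functional assay on MCF7 cells (Homo sapiens) for cytotoxicity, read by MTT assay, with a stated time of 72 h (on this read-out higher numbers stand for weaker inhibition and lower numbers for stronger inhibition), compound 3 gives 8210 nM. Compound 1 `O=C(Nc1ccc(Oc2ccnc3[nH]ccc23)cc1)c1ccc(-c2ccc(F)cc2F)cn1` reaches only a limit of this assay, > 10000 nM. Compound 2 `CCc1ccc(-c2ccc(C(=O)Nc3ccc(Oc4ccnc5[nH]ccc45)cc3)nc2)cc1` likewise returns a limit, > 10000 nM. Going by the values given here, the one step between measured compounds, a step that the two limits leave unreadable from compound 1 to compound 2, cannot be sized due to the limit of > 10000 nM in this assay, at which 2 of the 3 values shown sit.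

Compound 4 `O=C(Nc1ccc(Oc2ccnc3[nH]ccc23)cc1)c1cc(-c2ccccc2)ccn1` differs from compound 3 by hydrogen in place of methoxy on an aromatic carbon, placed on an aromatic carbon of a six-membered aromatic ring of carbon only, para to a large group; cut one bond further out this reads 4-methoxyphenyl to phenyl. Among the compounds with values here, no measured step in this assay involves removal of a methoxy, and the single measured step is unreadable, so nothing in the set points to a direction or a size. For compound 4 the step expected is a 1.2-fold higher number from compound 3 to compound 4 (0.06 log units; within the scatter), within the usual scatter. Compound 4 is therefore estimated at 9500 nM, in a range from 3500 nM to 28000 nM, with a substantial chance that this assay returns only a limit.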

Compound 4, half-maximal inhibitory concentration: 3750 nM
The estimate for compound 4 lay 2.5-fold (0.40 log units) above the measured number; measured number inside the range.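

In this assay, for the compounds shown here, replacing methoxy with hydrogen on the six-membered aromatic ring of carbon only gives a 2.2-fold lower number from compound 3 to compound 4 (0.34 log units; beyond the scatter), the first step that can be read. At this place, para to a large group, the methoxy is therefore not required for the read-out, and the plain phenyl gives the stronger inhibition, though by a modest margin. This single step is the only size available, and the other step cannot be read: the limit of > 10000 nM in this assay, at which 2 of the 4 values shown sit.

From the compounds shown here alone, whether an amine, a hydroxyl or a chlorine at this place would lower the number further remains open, as does the effect of a longer chain such as ethoxy. Going by these compounds, it is also open whether the same change would give a step of similar size on the core of compound 2.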